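A side chain swap among closely spaced values

The source may report more compounds than this note shows. Statements on the series, on what has been measured and on what is new or still open speak of the compounds shown alone.

Compound 1 `CNC(=O)C[C@@H]1C[C@@H](c2ccc(Cl)c(Cl)c2)[C@H](NC(=O)c2cc(-c3c(Cl)cnn3C)c(Cl)o2)CN1`: 1130 nM
Compound 2 `Cn1ncc(Cl)c1-c1cc(C(=O)N[C@@H]2CN[C@H](CC(N)=O)C[C@H]2c2ccc(Cl)c(Cl)c2)oc1Cl`: 1000 nM
Compound 3 `CN(C)CC[C@@H]1C[C@@H](c2ccc(Cl)c(Cl)c2)[C@H](NC(=O)c2cc(-c3c(Cl)cnn3C)c(Cl)o2)CN1`: 1510 nM

All three values come from a functional assay on OVCAR-8 cells (Homo sapiens) for antiproliferative activity; on this read-out higher numbers stand for weaker inhibition and lower numbers for stronger inhibition. Compound 3 stands level with the other two, since both steps that reach it lie within the usual scatter: a 1.3-fold higher number from compound 1 to compound 3 (0.13 log units; within the scatter), and a 1.5-fold higher number from compound 2 to compound 3 (0.18 log units; within the scatter). Each of those steps altered the same side chain that changes again now. Compound 4 `Cn1ncc(Cl)c1-c1cc(C(=O)N[C@@H]2CN[C@H](CC(=O)NCC(O)CO)C[C@H]2c2ccc(Cl)c(Cl)c2)oc1Cl` differs from compound 3 as follows: (2,3-dihydroxypropyl)carbamoyl in place of (dimethylamino)methyl on a saturated chain carbon bound to a saturated ring carbon. Like compound 1 and compound 2, compound 4 carries a carbamoyl group at this place, and the one step between those two amides was also small: a 1.1-fold lower number from compound 1 to compound 2 (0.05 log units; within the scatter). Among the measured compounds shown here, no measured compound carries the dihydroxypropyl chain, so these steps offer only a rough guide. Still, every step seen at this place stayed within the scatter, so no step beyond the scatter is expected in this assay, in either direction. The estimated change is a 1.3-fold lower number from compound 3 to compound 4 (0.12 log units; within the scatter). For compound 4 the expected value is 1150 nM, with an estimated range of 550 nM to 2500 nM.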

Compound 4, half-maximal inhibitory concentration: 5900 nM
Estimate against measurement, compound 4: 5.1-fold (0.71 log units) below; the whole stated range lies below it.
By their numbers in this assay, from the lowest: compounds 2, 1 and 3 (each within the scatter of the next); then compound 4.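

Among the compounds shown here, this side chain is not as forgiving as the earlier compounds suggested: replacing (dimethylamino)methyl with (2,3-dihydroxypropyl)carbamoyl gives the first step beyond the scatter at this place in this assay (a 3.9-fold higher number from compound 3 to compound 4 (0.59 log units; beyond the scatter)). The amide itself does not account for the change, as compound 1 and compound 2 also carry an amide here, yet compound 4 still reads weaker than compound 2 (a 5.9-fold higher number from compound 2 to compound 4 (0.77 log units; beyond the scatter)) and compound 1 (a 5.2-fold higher number from compound 1 to compound 4 (0.72 log units; beyond the scatter)). Methyl and hydrogen on the amide nitrogen stand level, so this position tolerates those small changes but responds to the larger 2,3-dihydroxypropyl chain. Nothing measured here explains this shift.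

The compounds shown do not separate the effect of the hydroxyl groups from that of chain length, a question that a plain propyl chain on the amide nitrogen would address. As far as these compounds go, how a carboxylic acid or a longer amine chain would read at this place also remains open.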